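Chain amines and a diamino amide in an activation assay

This account rests on a few compounds, and the source may have more. Where it says the series, first, only, none or still open, it means among the compounds named here.

Measured so far in a functional assay on HL-60 cells (Homo sapiens) for activation (a higher number here means that more compound is needed for the effect, a lower number that less compound is needed), with these values
Compound 1 `CCCCCCCCCCCCNCCN` gives 1000 nM
Compound 2 `CCCCCCCCCCCCNC(=O)CNC(=O)CN` gives 5010 nM
Compound 3 `CCCCCCCCCCCCNCCN=C(N)N` gives 1000 nM

Compound 2 has the highest number of the three, and compound 1 and compound 3 each lie below it by more than the scatter. Compound 4 `CCCCCCCCCCCCNC(=O)C(N)CCN` has not yet been measured. Its difference from compound 2 is 1,3-diaminopropyl in place of (((aminomethyl)carbonyl)amino)methyl on a carbonyl carbon and in words 1,3-diaminopropyl stands in place of (((aminomethyl)carbonyl)amino)methyl on a carbonyl carbon.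

For the measured compounds named here, only one measured step changes a single place, namely no change at the digits printed from compound 1 to compound 3 (within the scatter) and it concerns a different group, so it is a weak guide here. Compound 1 at 1000 nM and compound 3 at 1000 nM show that lower numbers occur in this series. The expected change is therefore small and downward, with a 2.0-fold lower number from compound 2 to compound 4 (0.30 log units; within the scatter) as the estimated step in this assay near the edge of the scatter. For compound 4 the estimate is 2500 nM with an expected range from 800 nM to 8000 nM in this assay.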

Compound 4, half-maximal effective concentration: 1260 nM
Beside the measured number, compound 4's estimate is 2.0-fold (0.30 log units) above it, within the range that was stated.
By their numbers in this assay, from the lowest: compounds 1, 3 and 4 (each within the scatter of the next); then compound 2.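

In this assay, 1,3-diaminopropyl in place of (((aminomethyl)carbonyl)amino)methyl on a carbonyl carbon gives a 4.0-fold lower number from compound 2 to compound 4 (0.60 log units; beyond the scatter). For the compounds shown here, this step lies beyond the scatter, whereas the only earlier single-place step, no change at the digits printed from compound 1 to compound 3 (within the scatter), did not, so this is the first sign that the number responds to a change in one place. The two groups have the same counts of hydrogen-bond donors and acceptors and neither has a ring, but only the group that leaves holds a double bond, and nothing measured here accounts for the step.

Going by these compounds alone, the single swap changes the whole group at once, leaving open whether the loss of that carbonyl or the new arrangement of the two amines matters. On these data alone, what a guanidine or a carboxylic acid in place of 1,3-diaminopropyl on a carbonyl carbon would give also remains open.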